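Adding a Second Fluorine to a Receptor Antagonist

The compounds below may be only part of what the source reports. "The series", "measured", "known", "first", "only" and "open" are said of these compounds alone.

Of the compounds shown here, three that share one core have been measured in a functional assay on cells for antagonist activity at Free fatty acid receptor 1 (Homo sapiens), read by TR-FRET and inositol phosphate accumulation, with a stated time of 2 h; a higher number here means a weaker inhibitor, a lower number a stronger inhibitor. Compound 1 `Cc1cc(COc2cccc(Cl)c2)nc(-c2ccccn2)n1` gives 398 nM. Compound 2 `Cc1cc(COc2cccc(F)c2)nc(-c2ccccn2)n1`, which carries a fluoro in place of the chloro, gives 794 nM. Compound 3 `Cc1cc(COc2cccc(F)c2F)nc(-c2ccccn2)n1`, with one further fluoro on the same ring, gives 398 nM. Going by the values given here, compound 2 stands apart from neither neighbour: the step of a 2.0-fold higher number from compound 1 to compound 2 (0.30 log units; within the scatter) and the step of a 2.0-fold lower number from compound 2 to compound 3 (0.30 log units; within the scatter) are both within the scatter, so no measured compound separates from compound 2 beyond it.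

Compound 4 `Cc1cc(COc2ccc(F)c(F)c2)nc(-c2ccccn2)n1` is not yet measured. It differs from compound 2 by fluoro in place of hydrogen on an aromatic carbon. Among the compounds with values here, the only measured step of the same kind, fluoro in place of hydrogen on this ring, is a 2.0-fold lower number from compound 2 to compound 3 (0.30 log units; within the scatter), which placed the new fluoro at a different position and stayed within the scatter. On that basis, no shift beyond the scatter is expected in this assay for compound 4; a small movement in either direction would be unsurprising, and a slight lowering is the more likely one.

The step from compound 2 to compound 4 is therefore estimated to be a 1.6-fold lower number from compound 2 to compound 4 (0.20 log units; within the scatter). Compound 4 is expected to give about 500 nM, most likely between 200 nM and 1250 nM.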

Compound 4, half-maximal inhibitory concentration: 501 nM
For compound 4 the middle estimate is 1.0-fold (0.00 log units) below the measured one; measured number inside the range.
By their numbers in this assay, from the lowest: compounds 1, 3, 4 and 2 (each within the scatter of the next).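

In this assay, adding a fluoro on the aromatic carbon that is ortho to a fluoro group and para to a large group gives a 1.6-fold lower number from compound 2 to compound 4 (0.20 log units; within the scatter), so this change does not separate the two compounds beyond the normal variation between repeated measurements. Read together with a 2.0-fold lower number from compound 2 to compound 3 (0.30 log units; within the scatter), it makes two placements of a second fluoro on this ring that stay within the scatter, which a single placement could not show. No measurement is available here that explains this result or tells what the added fluoro does at this position.

The compounds shown leave open whether this position can affect the number at all, since a small atom such as fluoro produces no step beyond the scatter and says little about how a different group would behave. A methoxy group, an amine or a carboxylic acid on the same carbon would test this more strongly, and only such a result could show whether the position truly tolerates change or has so far been probed too gently.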